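The compounds below may be only part of what the source reports. "The series", "measured", "known", "first", "only" and "open" are said of these compounds alone.

Measured so far:
compound 1, `COc1ccc(Cl)cc1C(=O)NCCC1CCN(S(=O)(=O)NC(=O)NC[C@@H]2C[C@@H]3C=C[C@@H]2C3)CC1`: 27%
compound 2, `O=C(NC[C@@H]1C[C@@H]2C=C[C@@H]1C2)NS(=O)(=O)N1CCC(CCNC(=O)c2cc(Cl)ccn2)CC1`: 16%
compound 3, `O=C(NC1CCCCC1)NS(=O)(=O)N1CCC(CCNC(=O)c2cccc3cccnc23)CC1`: 29%

All three were tested in a functional assay on the whole organism (blood) with Rattus norvegicus as the target, with stated times of 24 h and 1 h, at a dose of 1 mg/kg by the intraperitoneal route; a lower number here means a weaker effect, a higher number a stronger effect of the compound at the dose given. Compound 3 gives the highest of the three numbers, but its gap to compound 1 lies within the scatter, so only compound 2 stands clearly lower. Compound 4, `O=C(NC[C@@H]1C[C@@H]2C=C[C@@H]1C2)NS(=O)(=O)N1CCC(CCNC(=O)c2cccc3cccnc23)CC1`, differs from compound 3 in one place: a group of 8 heavy atoms (8 carbon; 2 five-membered non-aromatic rings of carbon only) in place of a group of 6 heavy atoms (6 carbon; one six-membered non-aromatic ring of carbon only), on an amide-type nitrogen. For the measured compounds named here, the only measured step, a number 11 percentage points lower from compound 1 to compound 2 (beyond the scatter), alters a different part of the molecule and does not bear on this swap. The entering group is already carried by compound 1 and compound 2, whose numbers in this assay sit within the scatter of compound 3 or modestly beneath it. The step of a number 4 percentage points lower from compound 3 to compound 4 (within the scatter) is therefore expected to stay within the scatter. Compound 4 is expected to give 25%, between 10% and 40%.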

Compound 4, a percentage reported as activity, at one dose (the size of the read-out at that dose, not a potency): 32%
The estimate for compound 4 lay 7 percentage points below the measured number; the range from low to high includes it.
By their numbers in this assay, from the lowest: compound 2; then compounds 1, 3 and 4 (each within the scatter of the next).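

On the amide-type nitrogen, the group of 8 carbon atoms with two five-membered rings can take the place of cyclohexyl without a readable change in this assay: the step is a number 3 percentage points higher from compound 3 to compound 4 (within the scatter). With that group kept, the group on the carbonyl carbon can matter: quinolin-8-yl against 4-chloropyridin-2-yl gives a number 16 percentage points higher from compound 2 to compound 4 (beyond the scatter), while quinolin-8-yl against 5-chloro-2-methoxyphenyl gives a number 5 percentage points higher from compound 1 to compound 4 (within the scatter). No measurement here explains these results. As far as these compounds go, whether cyclopentyl or an n-butyl chain on that nitrogen would give a similar number stays open.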